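Swapping a methyl for a methoxy on the aniline ring

The source may report more compounds than this note shows. Statements on the series, on what has been measured and on what is new or still open speak of the compounds shown alone.

Measured compounds:
Compound 1, `COC(=O)c1c(Nc2ccccc2)sc(C(=O)c2ccc(OC)cc2)c1C`: 13.3%
Compound 2, `COC(=O)c1c(Nc2ccc(C)cc2)sc(C(=O)c2ccc(OC)cc2)c1C`: "not active" (no number reported)

Both compounds share a core and differ only in the group carried on the ring attached to the nitrogen. In a functional assay, with a stated time of 150 min, tested at 5 ug/mL (a higher number here means a stronger effect of the compound at the concentration tested, a lower number a weaker effect), compound 1 gives 13.3%, a small effect. For compound 2 the result is "not active" (no number reported), with no number given, so compound 2 stands at the bottom of what the two measurements show, without a figure to pin it down. Among the compounds with values here, since no numbered pair of neighbours exists, no size for a step between them can be stated.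

Compound 3, `COC(=O)c1c(Nc2ccc(OC)cc2)sc(C(=O)c2ccc(OC)cc2)c1C`, has not yet been tested in this assay. It differs from compound 2 as follows: methoxy in place of methyl on an aromatic carbon. Given that compound 2 was reported without activity and compound 1 shows only a small effect, the expected step for compound 3 in this assay is none beyond the scatter, and the estimated value for compound 3 is 8%, within 0% to 25%.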

Compound 3, a percentage reported as activity, at one concentration (the size of the read-out at that concentration, not a potency): 4.29%
Compound 3: middle estimate off by 3.7 percentage points, on the high side; measured number inside the range.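

With methoxy at this position, para to a large group, the aniline ring still gives only a weak effect: in this assay, the step is a number 9 percentage points lower from compound 1 to compound 3 (within the scatter), so adding the group in place of hydrogen makes no change that stands clear of the usual scatter. The swap of methyl for methoxy cannot be read as a step, since compound 2 has no number, although compound 3 does give a measurable 4.29%. No other measurement here helps to explain this result.

From the compounds shown here alone, what remains open is whether any group at this position can raise the effect in this assay well beyond these small values. An amine, a carboxylic acid or a longer chain such as ethoxy could answer that, and the effect of changes elsewhere on the shared core is also unknown.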